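Quinoline stilbenes: Z to E configuration switch

The source may hold more compounds than are shown below. What is called first, only, known or untested is meant among the compounds shown, and "the series" means these compounds.

Measured so far:
compound 1, `COc1cc(/C=C\c2ccc3ccccc3n2)cc(OC)c1OC`: 316 nM
compound 2, `COc1cc(/C=C\c2cnc3ccccc3c2)cc(OC)c1OC`: 398 nM
compound 3, `COc1cc(/C=C\c2ccc3cccnc3c2)cc(OC)c1OC`: 158 nM

All three share a trimethoxyphenyl stilbene core drawn Z and differ in where the nitrogen sits in the bicyclic ring. In a functional assay on HCT-116 cells (Homo sapiens) for cytotoxicity (on this read-out higher numbers stand for weaker inhibition and lower numbers for stronger inhibition), compound 3 gives 158 nM, the lowest number of the three. Its nearest neighbour is compound 1 at 316 nM, a gap that lies within the scatter, so no order between compound 3 and compound 1 can be claimed. Compound 2 at 398 nM stands beyond the scatter from compound 3, so compound 3 inhibits more strongly than compound 2.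

Compound 4, `COc1cc(/C=C/c2ccc3cccnc3c2)cc(OC)c1OC`, is not yet measured. It keeps every atom and bond of compound 3: the two compounds have the same atoms and bonds and differ only in configuration as drawn: 1 of 1 stereo elements differ; a double bond is drawn Z in compound 3 and E in compound 4. Going by the values given here, no pair among the measured compounds shows the effect of this configurational change, so there is nothing in the present numbers to size the step from. The expectation is that the step of a 19-fold higher number from compound 3 to compound 4 (1.28 log units; beyond the scatter) runs toward a higher number, that is weaker inhibition, with wide uncertainty. Compound 4 is therefore estimated at 3000 nM in this assay, with a range from 500 nM to 20000 nM.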

Compound 4, half-maximal inhibitory concentration: 1580 nM
Compound 4: the middle estimate sits 1.9-fold (0.28 log units) above what was measured, and the stated range covers the measured number.
By their numbers in this assay, from the lowest: compounds 3, 1 and 2 (each within the scatter of the next, the first and the last beyond it); then compound 4.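

In this assay, a 10-fold higher number from compound 3 to compound 4 (1.00 log units; beyond the scatter), with the Z form giving the lower number and so the stronger inhibition. This step can be read on the double bond alone, and on no other part of the structure, because of one structural point: the fact that compounds 3 and 4 differ only in the configuration as drawn. Going by these compounds alone, the earlier compounds are all drawn Z, so they could show only differences in where the nitrogen sits; this pair is the first to show that the configuration of the double bond is itself a variable, and one that moves the number beyond the scatter.

As far as these compounds go, the finding rests on a single pair, so it holds for the nitrogen placement of compound 3, and whether the same switch gives a step of like size or direction with the placements of compound 1 or compound 2 remains open. Also open, from the compounds shown here alone, is how the Z form responds to changes elsewhere on the shared core, for example a hydroxyl or an amine on the bicyclic ring, or an amide in place of the double bond.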